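Piperazine aryl variation in a thiophene series

The compounds below may be only part of what the source reports. "The series", "measured", "known", "first", "only" and "open" are said of these compounds alone.

Compound 1 `Nc1scc(CN2CCN(c3ccc(Cl)c(C(F)(F)F)c3)CC2)c1C(=O)c1ccc(Cl)cc1` gives 3% in an assay on CHO cells for displacement of a labelled ligand from adenosine receptor A3 (Homo sapiens), read by scintillation counting, with a stated time of 120 min, tested at 10 uM; on this read-out lower numbers stand for less inhibition and higher numbers for more inhibition at the one concentration tested (going by the name of the read-out). Compound 2 `Nc1scc(CN2CCN(c3ccccc3F)CC2)c1C(=O)c1ccc(Cl)cc1` gives 0% in this assay, and compound 3 `Nc1scc(CN2CCN(c3cccc(Cl)c3)CC2)c1C(=O)c1ccc(Cl)cc1` gives 1%. The three numbers lie within the scatter of one another: a number 3 percentage points lower from compound 1 to compound 2 (within the scatter), a number 2 percentage points lower from compound 1 to compound 3 (within the scatter) and a number 1 percentage points higher from compound 2 to compound 3 (within the scatter). Compound 3 therefore stands among numbers that cannot be told apart on this read-out. Compound 4 `Nc1scc(CN2CCN(c3cc(Cl)ccc3Cl)CC2)c1C(=O)c1ccc(Cl)cc1` is not yet measured; it differs from compound 3 by chloro in place of hydrogen on an aromatic carbon. The measured steps all swap one aryl group for another on the same amine nitrogen, and none moved the read-out beyond the scatter. A further chloro on that aryl ring is therefore expected to leave compound 4 within the scatter of compound 3, as a number 1 percentage points higher from compound 3 to compound 4 (within the scatter). Compound 4 is estimated at 2%, expected between -6% and 10%.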

Compound 4, a percentage reported as inhibition, at one concentration (the size of the read-out at that concentration, not a potency): 1%
Estimate against measurement, compound 4: 1 percentage points above; the measured number falls inside the stated range.
By their numbers in this assay, from the lowest: compounds 2, 3, 4 and 1 (each within the scatter of the next).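

Chloro on the aromatic carbon ortho to a large group and para to a chloro group is the first single-position addition to this aryl ring, and in this assay it leaves the read-out within the scatter (no change at the digits printed from compound 3 to compound 4 (within the scatter)). The 2,5-dichlorophenyl group also stays within the scatter of the other aryl groups (a number 1 percentage points higher from compound 2 to compound 4 (within the scatter); a number 2 percentage points lower from compound 1 to compound 4 (within the scatter)). No measured evidence bears on this result.

The numbers give no ranking of these aryl groups. Going by these compounds, whether an amine or a carboxylic acid at this position would shift the read-out remains open.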